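Aryl Variation on a Thiazole Acetic Acid Series

The source may hold more compounds than are shown below. What is called first, only, known or untested is meant among the compounds shown, and "the series" means these compounds.

Compound 3 `COc1cc(-c2nc(C(c3ccc(F)cc3)c3ccc(F)cc3)sc2CC(=O)O)ccn1` gives 380 nM in an in vitro functional assay on HEK285-7 cells for antagonist activity at prostaglandin D2 receptor 2 (Homo sapiens), read by BRET and beta-arrestin recruitment (on this read-out lower numbers stand for stronger inhibition and higher numbers for weaker inhibition), the lowest number among the three measured compounds. Compound 1 `N#Cc1ccc(-c2nc(C(c3ccc(F)cc3)c3ccc(F)cc3)sc2CC(=O)O)cc1` gives 1500 nM, and the step of a 3.9-fold lower number from compound 1 to compound 3 (0.60 log units; beyond the scatter) lies beyond the scatter. Compound 2 `N#Cc1cc(-c2nc(C(c3ccc(F)cc3)c3ccc(F)cc3)sc2CC(=O)O)ccc1F` gives 520 nM, and the step of a 1.4-fold lower number from compound 2 to compound 3 (0.14 log units; within the scatter) stays within the scatter. Compound 4 `Cc1cc(-c2nc(C(c3ccc(F)cc3)c3ccc(F)cc3)sc2CC(=O)O)cnc1N` carries 6-amino-5-methylpyridin-3-yl in place of 2-methoxypyridin-4-yl on an aromatic carbon. For the measured compounds named here, the steps that bear on it all exchange the same aryl group: a 2.9-fold lower number from compound 1 to compound 2 (0.46 log units; beyond the scatter) and a 3.9-fold lower number from compound 1 to compound 3 (0.60 log units; beyond the scatter) are modest, while a 1.4-fold lower number from compound 2 to compound 3 (0.14 log units; within the scatter) is within the scatter. In this assay compound 4 is therefore expected to land close to compound 3, with the step of a 1.3-fold higher number from compound 3 to compound 4 (0.12 log units; within the scatter) not clearly beyond the scatter. The estimate for compound 4 is 500 nM, ranging from 150 nM to 1600 nM.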

Compound 4, half-maximal inhibitory concentration: > 100000 nM
Compound 4 gave a limit, no number; the forecaster's own chance of this, stated with the estimate: 5%; at least 200-fold (2.30 log units) between middle value and limit.
By their numbers in this assay, from the lowest: compounds 3 and 2 (each within the scatter of the next); then compound 1. At a limit, above all of these: compound 4.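

Compound 4 gives a limit in this position, not a number: the limit of > 100000 nM in this assay, at which 1 of the 4 values shown sits.

Earlier exchanges of the aryl group on this aromatic carbon were modest or within the scatter in this assay, whereas 6-amino-5-methylpyridin-3-yl gives large steps against all three earlier groups (an at least 260-fold higher number from compound 3 to compound 4 (2.42 log units; beyond the scatter)), (an at least 190-fold higher number from compound 2 to compound 4 (2.28 log units; beyond the scatter)) and (an at least 66-fold higher number from compound 1 to compound 4 (1.82 log units; beyond the scatter)). Compound 3 and compound 4 both carry a six-membered aromatic ring with 1 hetero atom, so that ring alone does not secure a measurable number here.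

The compounds shown do not separate the contribution of the amine from that of the methyl group. As far as these compounds go, whether a hydroxyl or an acetamide in place of the amine would restore a measurable number also stays open.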